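Nitro in Place of Fluoro on the Shared Core

The source may report more compounds than this note shows. Statements on the series, on what has been measured and on what is new or still open speak of the compounds shown alone.

Compound 1 `O=C1C(=O)N(CCCCn2cc(COc3cc(=O)oc4ccccc34)nn2)c2ccc(F)cc21` was tested in a functional assay on COLO 205 cells (Homo sapiens) for inhibition, read by sulforhodamine B assay, with a stated time of 48 h, tested at 50 uM (on this read-out lower numbers stand for less inhibition of growth and higher numbers for more inhibition of growth at the one concentration tested), where compound 1 gives 64%. Among the compounds with values here, its only companion is compound 2 `O=C1C(=O)N(CCCCCn2cc(COc3cc(=O)oc4ccccc34)nn2)c2ccc(Br)cc21`; in this assay compound 2 gives 39%, a number that lies beyond the scatter below compound 1, so compound 1 holds the higher of the two numbers. Compound 3 `O=C1C(=O)N(CCCCn2cc(COc3cc(=O)oc4ccccc34)nn2)c2ccc([N+](=O)[O-])cc21` is not yet measured. It differs from compound 1 in one place: nitro in place of fluoro on an aromatic carbon. Within the data shown here, no measured pair bridges such a change, so the expected step of a number 4 percentage points lower from compound 1 to compound 3 (within the scatter) is none beyond the scatter. Compound 3 is therefore expected to give 60%, within 35% to 85%.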

Compound 3, percent growth inhibition at one concentration: 45%
Estimate against measurement, compound 3: 15 percentage points above, and the stated range covers the measured number.
By their numbers in this assay, from the lowest: compounds 2 and 3 (each within the scatter of the next); then compound 1.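

With the chain and the rest of the shared core unchanged, nitro in place of fluoro in this assay gives a number 19 percentage points lower from compound 1 to compound 3 (beyond the scatter). Within the data shown here, this is the first step read at this aromatic carbon, and it shows that the growth-inhibition number responds to the group placed there. Nothing at hand explains why the number responds to this change.

On these data alone, whether an amine or a methoxy group on this carbon would stay close to compound 1 or fall as nitro does remains open. So does whether the same step would appear with a longer chain.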